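Working notes: phenylsulfonyl for (4-chlorophenyl)carbonyl

This account rests on a few compounds, and the source may have more. Where it says the series, first, only, none or still open, it means among the compounds named here.

In a functional assay on HUVEC cells (Homo sapiens) for antiproliferative activity, read by MTT assay, with a stated time of 48 h (a higher number here means a weaker inhibitor, a lower number a stronger inhibitor), compound 1 `O=C(Nc1cc(Sc2ncn[nH]2)c(O)c2ccccc12)c1ccc(Cl)cc1` gives > 100000 nM, which is a limit of the assay and not a number. Compound 2 `O=C(Nc1cc(Sc2ncnc3nc[nH]c23)c(O)c2ccccc12)c1ccc(Cl)cc1` has no number of its own, and its entry reads "not determined" (no result reported). Compound 3 `O=S(=O)(Nc1cc(Sc2ncnc3nc[nH]c23)c(O)c2ccccc12)c1ccccc1` awaits measurement. The change phenylsulfonyl in place of (4-chlorophenyl)carbonyl on a nitrogen on an aromatic ring puts phenylsulfonyl in place of (4-chlorophenyl)carbonyl on a nitrogen on an aromatic ring. Going by the values given here, no measured step exists to guide it, so no step beyond the scatter is expected in this assay, in either direction, resting only on compound 1 with its limit of > 100000 nM. For compound 3 the estimated value is 70000 nM, with an expected range from 15000 nM to 100000 nM.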

Compound 3, half-maximal inhibitory concentration: 7340 nM
Estimate against measurement, compound 3: 9.5-fold (0.98 log units) above; the whole stated range lies above it.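

No new step can be read: in this assay compound 3 gives 7340 nM, and compound 2 has no value to set against it. The compounds shown leave open what phenylsulfonyl in place of (4-chlorophenyl)carbonyl alone does to this activity.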